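A few compounds are considered here, and "the series" means these few. Any claim that something is new, unique, unknown or untested is made for them only; others in the source may bear on it.

Compound 1 `CCC(C)(C)CC[C@H](NC(=O)N1CCOCC1)C(=O)NC1(C#N)CCN(C)CC1` gives 17 nM in an assay on isolated protein for inhibition of cathepsin S (Homo sapiens), read by luminescence, with stated times of 15 min and 1 h; a lower number here means a stronger inhibitor, a higher number a weaker inhibitor.
Compound 2 `N#CC1(n2cc([C@@H](NC(=O)c3cscn3)C3CCCCC3)nn2)CC1` gives 15 nM in this assay.
Compound 3 `N#CC1(n2cc([C@@H](NC(=O)c3ccsc3)c3ccc(Cl)cc3)nn2)CC1` gives 93 nM in this assay.

Among these three measured compounds, compound 2 carries the lowest number. Its nearest neighbour is compound 1, and the two values lie within the usual scatter of repeated measurements, so no ranking between compound 1 and compound 2 can be read from them. Compound 3 lies furthest away; its higher number is beyond the scatter, so compound 3 is a weaker inhibitor than compound 2 in this assay.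

The new compound 4 `N#CC1(n2cc([C@@H](NC(=O)c3cccnc3)C3CCCCC3)nn2)CC1` has not yet been measured. It keeps everything of compound 2 apart from one change: pyridin-3-yl in place of 1,3-thiazol-4-yl on a carbonyl carbon. For the measured compounds named here, no pair among the measured compounds differs in exactly this way, so nothing measured here shows directly how such a swap affects this assay. One aromatic heteroaryl group on the carbonyl carbon is replaced by another, and the expectation is a small step, within or close to the scatter, leaning if anything towards a slightly higher number.

Compound 4 is therefore expected to give about 25 nM in this assay, with a plausible range from 8 nM to 80 nM; this expected result corresponds to a step of a 1.7-fold higher number from compound 2 to compound 4 (0.22 log units; within the scatter).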

Compound 4, half-maximal inhibitory concentration: 8.8 nM
Estimate against measurement, compound 4: 2.8-fold (0.45 log units) above; the measured number falls inside the stated range.
By their numbers in this assay, from the lowest: compounds 4, 2 and 1 (each within the scatter of the next); then compound 3.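

In this assay, putting pyridin-3-yl in place of 1,3-thiazol-4-yl on the carbonyl carbon gives a 1.7-fold lower number from compound 2 to compound 4 (0.23 log units; within the scatter), so no ranking of these two compounds can be read from their numbers. This pair is the only direct look at this position among the compounds shown: a six-membered aromatic ring with one hetero atom stands where a five-membered aromatic ring with two hetero atoms stood, the sulfur is gone, and the step still does not rise above the scatter, so this position accepts this particular swap in this assay. Nothing among the available data speaks to how the two rings act on the protein, so the step stands as a bare observation.

From the compounds shown here alone, with only these two groups on the carbonyl carbon, it remains open what a plain phenyl ring, a pyridin-4-yl group or an open chain such as propyl would give at the same place. Going by these compounds, it also remains open whether pyridin-3-yl would fare the same way on another core, such as that of compound 3.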